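Adding a Methylpiperidine Ring and Exposure After Oral Dosing

A few compounds are considered here, and "the series" means these few. Any claim that something is new, unique, unknown or untested is made for them only; others in the source may bear on it.

Compound 1 `Cc1nc(C)n(CC(=O)N2CCN(c3sc(C(F)(F)F)nc3-c3nc4ccc(C5CCOCC5)cc4[nH]3)C[C@H]2C)n1`: 3360 nM
Compound 2 `Cc1nc(C)n(CC(=O)N2CCN(c3sc(C(F)(F)F)nc3-c3nc4ccccc4[nH]3)C[C@H]2C)n1`: 10100 nM
Compound 3 `C[C@@H]1CN(c2sc(C(F)(F)F)nc2-c2nc3ccccc3[nH]2)CCN1C(=O)Cn1cnc2cccnc21`: 53000 nM

In an ADME assay on the whole organism (Mus musculus, strain Balb/c) for pharmacokinetics, at a dose of 10 mg/kg by the oral route (a lower number here means less compound in the circulation, a higher number more compound in the circulation at the dose given), compound 2 gives 10100 nM, the second highest of these three numbers. The step of a 3.0-fold higher number from compound 1 to compound 2 (0.48 log units; beyond the scatter) came with hydrogen replacing oxan-4-yl, and the step of a 5.2-fold higher number from compound 2 to compound 3 (0.72 log units; beyond the scatter) came with a change of the group on the chain carbon next to the carbonyl. Compound 4 `Cc1nc(C)n(CC(=O)N2CCN(c3sc(C(F)(F)F)nc3-c3nc4ccc(C5CCN(C)CC5)cc4[nH]3)C[C@H]2C)n1` differs from compound 2 by 1-methylpiperidin-4-yl in place of hydrogen on an aromatic carbon. For the measured compounds named here, only the step of a 3.0-fold higher number from compound 1 to compound 2 (0.48 log units; beyond the scatter) bears on this, since it concerns a ring of similar size at the same aromatic carbon, and there its removal raised the number. Putting a comparable ring back is therefore expected to lower the number modestly, as a 3.4-fold lower number from compound 2 to compound 4 (0.53 log units; beyond the scatter). Compound 4 is estimated to give 3000 nM, within 1000 nM to 9000 nM.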

Compound 4, maximal plasma concentration: 50.7 nM
The estimate for compound 4 lay 59-fold (1.77 log units) above the measured number, and the stated range ends above it.
By their numbers in this assay, from the lowest: compound 4; then compound 1; then compound 2; then compound 3.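

Putting 1-methylpiperidin-4-yl on this aromatic carbon gave a 200-fold lower number from compound 2 to compound 4 (2.30 log units; beyond the scatter) in this assay, far more than the earlier oxan-4-yl step suggested. Exchanging oxan-4-yl for this group, also a six-membered non-aromatic ring, gave a 66-fold lower number from compound 1 to compound 4 (1.82 log units; beyond the scatter), so at this position the make-up of the ring matters, not only the presence of one. No measurement given here explains the drop.

As far as these compounds go, whether piperidin-4-yl without the methyl, or an open-chain amine, would give as low a number at this carbon stays open. So does whether 1-methylpiperidin-4-yl would have the same effect on compound 3.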